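Working notes on a small cytotoxicity series, compound 4 pending

This account rests on a few compounds, and the source may have more. Where it says the series, first, only, none or still open, it means among the compounds named here.

Measured compounds:
compound 1 `O=C1C=C(Nc2ccccc2)C(=O)c2scnc21` — 14.7 ug/mL
compound 2 `CCOc1ccc(NC2=CC(=O)c3sc(C)nc3C2=O)cc1` — 4.9 ug/mL
compound 3 `Cc1nc2c(s1)C(=O)C=C(Nc1cccc(Cl)c1)C2=O` — 5.7 ug/mL

All three were run in a functional assay on HepG2 cells (Homo sapiens) for cytotoxicity, read by MTT assay; on this read-out higher numbers stand for weaker inhibition and lower numbers for stronger inhibition. Compound 2 has the lowest of the three numbers, but compound 3 sits within the scatter of it, so the two cannot be told apart on these data. Within the data shown here, compound 1 is the only clearly separated member: its value lies beyond the scatter above that of compound 2, and it is also the one compound without the methyl on the shared core and without a substituent on the aryl ring.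

The next compound, compound 4 `Cc1nc2c(s1)C(=O)C=C(Nc1ccc(C(F)(F)F)cc1)C2=O`, is not yet measured in this assay. It differs from compound 2 in one place: trifluoromethyl in place of ethoxy on an aromatic carbon.

Among the measured compounds shown here, no pair differing in a single position has been measured, so no calibrating step exists for this change. What the data show is that two different ring substituents, in compound 2 and compound 3, give values within the scatter of each other. The expectation is therefore a step of no size beyond the scatter, with the estimate for compound 4 meaning a 1.1-fold higher number from compound 2 to compound 4 (0.05 log units; within the scatter). Compound 4 is expected to give about 5.5 ug/mL, in a range from 2.5 ug/mL to 12 ug/mL.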

Compound 4, half-maximal inhibitory concentration: > 100 ug/mL
Compound 4 ended at the assay's limit; the forecaster's own chance of this, stated with the estimate: 5%; at least 18-fold (1.25 log units) between middle value and limit.
By their numbers in this assay, from the lowest: compounds 2 and 3 (each within the scatter of the next); then compound 1. At a limit, above all of these: compound 4.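

Trifluoromethyl in place of ethoxy on an aromatic carbon, para to a large group, gives the first single-change step in the series: an at least 20-fold higher number from compound 2 to compound 4 (1.30 log units; beyond the scatter). Among these compounds, this shows that the group at this position can decide the read-out, which the earlier compounds could not show, as none of them formed a pair differing in one place. In this assay compound 4 gives > 100 ug/mL, which is a limit of the assay and not a number: the limit of > 100 ug/mL in this assay, at which 1 of the 4 values shown sits.

The compounds shown leave open whether the step follows from the loss of ethoxy, the entry of trifluoromethyl, or both, and a single change cannot separate these parts of the swap. Also open, as far as these compounds go, is how the read-out moves with other groups on this aromatic carbon, such as a methoxy, an amine or a carboxylic acid, and whether the same change gives a step of similar size on the core of compound 1, which lacks the methyl present in compound 2 and compound 4.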